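From Trifluoromethoxy to Carboxy: Estimating Compound 4

A few compounds are considered here, and "the series" means these few. Any claim that something is new, unique, unknown or untested is made for them only; others in the source may bear on it.

Of the compounds shown here, three sharing one core have been tested in an assay on isolated protein for inhibition of Rho-associated protein kinase 2 (Homo sapiens), read by scintillation counting, radiometric assay and 33P incorporation, with a stated time of 40 min, in the presence of a further agent that is not named here; on this read-out lower numbers stand for stronger inhibition and higher numbers for weaker inhibition. Compound 1 `O=C(COc1ccc2c(=O)ccoc2c1)Nc1cccc(NC(=O)c2ccc(F)cc2)c1` gives 54 nM, compound 2 `CCOc1ccc(C(=O)Nc2cccc(NC(=O)COc3ccc4c(=O)ccoc4c3)c2)cc1` gives 9 nM, and compound 3 `O=C(COc1ccc2c(=O)ccoc2c1)Nc1cccc(NC(=O)c2ccc(OC(F)(F)F)cc2)c1` gives 77 nM, the highest of the three numbers, though its gap to compound 1 lies within the scatter. The change to compound 4 `O=C(COc1ccc2c(=O)ccoc2c1)Nc1cccc(NC(=O)c2ccc(C(=O)O)cc2)c1` is carboxy in place of trifluoromethoxy on an aromatic carbon. Going by the values given here, no measured step involves a carboxy group; the nearest guidance is that a 1.4-fold higher number from compound 1 to compound 3 (0.15 log units; within the scatter) mattered little, while a 6.0-fold lower number from compound 1 to compound 2 (0.78 log units; beyond the scatter) and an 8.6-fold higher number from compound 2 to compound 3 (0.93 log units; beyond the scatter) show that groups at this position can move the number either way. With nothing pointing one way, the expected step is a 1.3-fold higher number from compound 3 to compound 4 (0.11 log units; within the scatter), carrying a wide range. Compound 4 is therefore estimated at 100 nM, between 25 nM and 400 nM.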

Compound 4, half-maximal inhibitory concentration: 2030 nM
The estimate for compound 4 lay 20-fold (1.31 log units) below the measured number; measured number outside the range, above it.
By their numbers in this assay, from the lowest: compound 2; then compounds 1 and 3 (each within the scatter of the next); then compound 4.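

Carboxy is the first group at this position to raise the number sharply against every other group shown (a 26-fold higher number from compound 3 to compound 4 (1.42 log units; beyond the scatter); a 38-fold higher number from compound 1 to compound 4 (1.58 log units; beyond the scatter); a 230-fold higher number from compound 2 to compound 4 (2.35 log units; beyond the scatter)). Until now, fluoro and trifluoromethoxy lay within the scatter of each other and ethoxy lowered the number, so no group had shown a loss of this size. Nothing measured here explains that loss.

As far as these compounds go, whether a methyl ester or an amide in place of the carboxy would restore the lower numbers remains open. So does whether an alkoxy chain longer than ethoxy would lower the number further.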